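The source may report more compounds than this note shows. Statements on the series, on what has been measured and on what is new or still open speak of the compounds shown alone.

Measured so far in an ADME assay on MT4 cells (Homo sapiens) for cytotoxicity, read by MTT assay, with a stated time of 5 days (a lower number here means that less compound is tolerated, a higher number that more compound is tolerated), each entry a limit of the assay and not a number:
compound 1 `CCNc1cc(Oc2c(OC)cc3cc(C#N)ccc3c2OC)nc(Nc2ccc(C#N)cc2)n1`: > 125000 nM
compound 2 `COc1cc2cc(C#N)ccc2c(OC)c1Oc1cc(NCC(C)(C)C)nc(Nc2ccc(C#N)cc2)n1`: > 125000 nM
compound 3 `CCCCCC(C)Nc1cc(Oc2c(OC)cc3cc(C#N)ccc3c2OC)nc(Nc2ccc(C#N)cc2)n1`: > 125000 nM

Compound 3 reads > 125000 nM in this assay and so has only a limit to its name. The same holds for the other two compounds, and the whole evidence is the limit of > 125000 nM in this assay, at which 3 of the 3 values shown sit, with nothing finer to go on.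

Compound 4 `COc1cc2cc(C#N)ccc2c(OC)c1Oc1cc(NC2CC2)nc(Nc2ccc(C#N)cc2)n1` carries cyclopropyl in place of 1-methylhexyl on a nitrogen on an aromatic ring and keeps the rest of the structure of compound 3.

The measured steps that bear on this change all alter the group on that same nitrogen. They are a step that the two limits leave unreadable from compound 1 to compound 2 and a step that the two limits leave unreadable from compound 1 to compound 3 and also a step that the two limits leave unreadable from compound 2 to compound 3 with none of them giving a size. No direction can be read from them, and none of the three compounds shows a measurable value. A step beyond the usual scatter is therefore not expected in this assay for this change.

The expected change is a number no higher from compound 3 to compound 4 (the limit leaves the size open) and no more than that can be claimed. Compound 4 is estimated at 125000 nM with an expected range of 50000 nM to 125000 nM and will most likely be reported as a limit again.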

Compound 4, half-maximal cytotoxic concentration: > 125000 nM
Compound 4: only a limit was reported (the forecaster's own chance of this, stated with the estimate: 75%); the middle value lies on the limit itself.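

In this assay compound 4 gives > 125000 nM as a limit of the assay and not a number. Among these compounds, no step from compound 4 to compound 1, compound 2 or compound 3 can be read. The compounds shown leave open at what concentration any of them becomes cytotoxic, and whether the group on the nitrogen changes that concentration.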